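Swapping the cyclobutylmethyl of compound 3 for a directly bound phenyl

The source may report more compounds than this note shows. Statements on the series, on what has been measured and on what is new or still open speak of the compounds shown alone.

Compound 3 `O=C(O)c1ccccc1-c1ccc(CCc2ncc(CC3CCC3)[nH]2)cc1` gives 588 nM in an in vitro functional assay on cells for agonist activity at Bombesin receptor subtype-3 (Homo sapiens), read by luminescence and calcium flux (a higher number here means that more compound is needed for the effect, a lower number that less compound is needed), the second highest of three numbers: compound 2 `O=C(O)c1ccccc1-c1ccc(CCc2ncc(Cc3cccc(Cl)c3)[nH]2)cc1` gives 825 nM, and a 1.4-fold lower number from compound 2 to compound 3 (0.15 log units; within the scatter), while compound 1 `O=C(O)c1ccccc1-c1ccc(CCc2ncc(Cc3ccccc3F)[nH]2)cc1` gives 177 nM, and a 3.3-fold higher number from compound 1 to compound 3 (0.52 log units; beyond the scatter). The change to compound 4 `O=C(O)c1ccccc1-c1ccc(CCc2ncc(-c3ccccc3)[nH]2)cc1` is phenyl in place of cyclobutylmethyl on an aromatic carbon. Going by the values given here, no measured step touches this position; the steps of a 4.7-fold higher number from compound 1 to compound 2 (0.67 log units; beyond the scatter) and a 3.3-fold higher number from compound 1 to compound 3 (0.52 log units; beyond the scatter) only show that the side group matters modestly. Because of a 1.4-fold lower number from compound 2 to compound 3 (0.15 log units; within the scatter), swapping one ring-bearing group for another need not move the number, so compound 4 is expected to show a 1.0-fold higher number from compound 3 to compound 4 (0.01 log units; within the scatter), with wide uncertainty. Compound 4 is estimated at 600 nM, between 150 nM and 2500 nM.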

Compound 4, half-maximal effective concentration: 4950 nM
Compound 4: the middle estimate sits 8.3-fold (0.92 log units) below what was measured; measured number outside the range, above it.
By their numbers in this assay, from the lowest: compound 1; then compounds 3 and 2 (each within the scatter of the next); then compound 4.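

In this assay, a ring bound directly to this aromatic carbon reads far higher than any of the chain-linked groups, with an 8.4-fold higher number from compound 3 to compound 4 (0.93 log units; beyond the scatter) and a 6.0-fold higher number from compound 2 to compound 4 (0.78 log units; beyond the scatter) and also a 28-fold higher number from compound 1 to compound 4 (1.45 log units; beyond the scatter). The position therefore tolerates swaps among cyclobutylmethyl, 3-chlorobenzyl and 2-fluorobenzyl far better than this change to phenyl. Nothing available explains this shift.

An unsubstituted benzyl or a directly bound cyclobutyl would separate the loss of the saturated chain carbon from the identity of the ring. Going by these compounds, how an amine or a longer chain would read at this carbon remains open.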